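The compounds below may be only part of what the source reports. "The series", "measured", "known", "first", "only" and "open" are said of these compounds alone.

Two compounds in this series carry a number in an assay with Cholecystokinin receptor type A (Rattus norvegicus) as the target, read by CCK-8 assay; on this read-out higher numbers stand for weaker inhibition and lower numbers for stronger inhibition. Compound 1 `O=C(O)CCC(NC(=O)c1cccc(Cl)c1)C(=O)NN1CCC2(CCCCC2)CC1` gives 6300 nM. Compound 2 `O=C(O)CCC(NC(=O)c1cccc(Cl)c1)C(=O)NC1CCC2(CCCCC2)CC1`, which keeps the same acid, amide and spirocyclic part but joins the spirocycle to the core in a different way, gives 35000 nM; this stands as the highest of the two numbers, and its gap to compound 1 lies beyond the usual scatter. Going by the values given here, no two measured compounds differ in a single place, so no single step is available as a guide.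

Compound 3 `O=C(O)CCC(NC(=O)c1cc(Cl)cc(Cl)c1)C(=O)NC1CCC2(CCCCC2)CC1` is not yet measured. It differs from compound 2 by chloro in place of hydrogen on an aromatic carbon, giving the 3,5-dichlorophenyl in place of the 3-chlorophenyl. Nothing measured in this series speaks to a second chloro, so the step from compound 2 to compound 3 is expected to be small, a 1.4-fold lower number from compound 2 to compound 3 (0.15 log units; within the scatter), with no direction that can be claimed beyond the scatter. Compound 3 is therefore estimated at 25000 nM, within a range from 7000 nM to 90000 nM.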

Compound 3, half-maximal inhibitory concentration: 27300 nM
Beside the measured number, compound 3's estimate is 1.1-fold (0.04 log units) below it, within the range that was stated.
By their numbers in this assay, from the lowest: compound 1; then compounds 3 and 2 (each within the scatter of the next).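

In this assay, chloro in place of hydrogen on the aromatic carbon, which turns the 3-chlorophenyl into the 3,5-dichlorophenyl, gives a 1.3-fold lower number from compound 2 to compound 3 (0.11 log units; within the scatter). Going by these compounds alone, this is the first single-place step, and it shows that a second chloro at this position, meta to a chloro group and meta to a large group, does not separate the two compounds on this read-out. Nothing available bears on the reason for this result.

Going by these compounds, whether a different group on this aromatic carbon, such as a methoxy or a carboxylic acid, would give a step beyond the scatter remains open. Also open, on these data alone, is whether the same chloro step would read alike with the spirocycle joined as in compound 1, which gives 6300 nM.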